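From benzyl to 4-hydroxybenzyl at the assay limit

The compounds below may be only part of what the source reports. "The series", "measured", "known", "first", "only" and "open" are said of these compounds alone.

Compound 1, `COc1ccc2c(c1)cc(-c1cc(OC)c(OC)c(OC)c1)n2Cc1ccccc1`, was tested in a functional assay on MCF7 cells (Homo sapiens) for cytotoxicity, read by MTT assay, with a stated time of 24 h; on this read-out higher numbers stand for weaker inhibition and lower numbers for stronger inhibition. Here compound 1 gives > 30000 nM, which is a limit and not a number. Compound 2, `COc1ccc2c(c1)c(Cc1ccccc1)c(-c1cc(OC)c(OC)c(OC)c1)n2Cc1ccccc1`, carries a further benzyl in place of hydrogen on an aromatic carbon. Compound 2 gives > 30000 nM, again a limit. Going by the values given here, the one measured step, a step that the two limits leave unreadable from compound 1 to compound 2, therefore has no readable size. What the data offer is the limit of > 30000 nM in this assay, at which 2 of the 2 values shown sit.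

Compound 3, `COc1ccc2c(c1)cc(-c1cc(OC)c(OC)c(OC)c1)n2Cc1ccc(O)cc1`, differs from compound 1 by hydroxy in place of hydrogen on an aromatic carbon. In plain terms, its benzyl becomes 4-hydroxybenzyl. Among the compounds with values here, no measured step tests a hydroxy group, so this change has no direct precedent in the data. Within the data shown here, the only guide is compound 1, with its limit of > 30000 nM. In this assay, no clear step in either direction is expected, and a further limit is the likeliest report. The expected change is a number no higher from compound 1 to compound 3 (the limit leaves the size open). For compound 3 the estimated value is 30000 nM, with an expected range from 10000 nM to 60000 nM.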

Compound 3, half-maximal inhibitory concentration: > 30000 nM
Compound 3: no number, only a limit; the forecaster's own chance of this, stated with the estimate: 70%; the middle value lies on the limit itself.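

Compound 3 gives > 30000 nM in this assay, which is a limit and not a number. Going by these compounds alone, compound 1 is also reported only as a limit, so no step from compound 1 to compound 3 can be read. Still open is whether benzyl and 4-hydroxybenzyl differ at all, and what would bring a readable number, since the results so far share one value: the limit of > 30000 nM in this assay, at which 3 of the 3 values shown sit.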